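A few compounds are considered here, and "the series" means these few. Any claim that something is new, unique, unknown or untested is made for them only; others in the source may bear on it.

Measured so far:
compound 1, `CCN(Cc1ccccc1)C(=O)C1CCN(S(=O)(=O)c2ccc(OC)cc2)CC1`, 84%
compound 2, `CCN(Cc1ccccc1)C(=O)C1CCN(S(=O)(=O)c2ccc3cccnc3c2)CC1`, 66%

Compound 2 holds the lowest of the two numbers in a functional assay on CHO cells for positive allosteric modulation of muscarinic acetylcholine receptor M5 (Homo sapiens), read by calcium flux; on this read-out lower numbers stand for smaller maximal responses and higher numbers for larger maximal responses. Among the compounds with values here, its nearest neighbour is compound 1, and the one recorded step, a number 18 percentage points lower from compound 1 to compound 2 (beyond the scatter), lies beyond the scatter and sets compound 2 as the lower of the pair.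

Compound 3, `CCN(Cc1ccccc1)C(=O)C1CCN(S(=O)(=O)c2ccc3cn[nH]c3c2)CC1`, is the next member: 1H-indazol-6-yl in place of quinolin-7-yl on a sulfonyl sulfur. Within the data shown here, the only measured step that bears on this change is the earlier exchange on the sulfonyl sulfur, a number 18 percentage points lower from compound 1 to compound 2 (beyond the scatter), where a six-membered aromatic ring with 1 hetero atom fused to a six-membered aromatic ring of carbon only replaced 4-methoxyphenyl. Among the measured compounds shown here, for compound 3 the group on the sulfonyl sulfur changes again, to 1H-indazol-6-yl, bringing a five-membered aromatic ring with 2 hetero atoms and 1 hydrogen-bond donor in place of quinolin-7-yl; no measured pair shows that swap. For the measured compounds named here, with a single modest step as the only guide, the expected step of a number 4 percentage points lower from compound 2 to compound 3 (within the scatter) is small, within or near the scatter, and its direction is open. Compound 3 is therefore estimated at 62%, in the range 45% to 80%.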

Compound 3, largest response reached (reported as percent of maximum), in percent of the reference or control that the assay uses: 86%
Estimate against measurement, compound 3: 24 percentage points below; measured number above the stated range.
By their numbers in this assay, from the lowest: compound 2; then compounds 1 and 3 (each within the scatter of the next).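

Changing the fused group on the sulfonyl sulfur moves the response in this assay: the result is a number 20 percentage points higher from compound 2 to compound 3 (beyond the scatter) and shows that the lower number of compound 2 does not carry over to every fused aromatic pair at this position. Against the monocyclic group, the result is a number 2 percentage points higher from compound 1 to compound 3 (within the scatter), so 1H-indazol-6-yl and 4-methoxyphenyl stand level here, and among these three compounds only quinolin-7-yl sits apart, despite the clear difference in ring make-up between the two groups that give the level numbers. Nothing available accounts for the gap between the two fused groups.

The exchange of quinolin-7-yl for 1H-indazol-6-yl alters ring size, nitrogen count and hydrogen-bond donor count in one move, so these compounds do not separate the contribution of each; a 1-methylindazol-6-yl group, which carries a methyl in place of the ring hydrogen on nitrogen, or a 4-aminophenyl group would bear on the donor question. Also open, as far as these compounds go, is how far these numbers hold when the ethyl and benzyl groups on the amide nitrogen, common to all three compounds, are replaced, for instance by a longer chain such as propyl.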